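The compounds below may be only part of what the source reports. "The series", "measured", "known", "first", "only" and "open" are said of these compounds alone.

Of the compounds shown here, three built on a shared core have been measured in a functional assay on KYSE-450 cells (Homo sapiens) for inhibition, read by MTT assay, with a stated time of 48 h; a lower number here means a stronger inhibitor, a higher number a weaker inhibitor. Compound 1 `COc1ccc(CN(C(=O)C=C(C)C)c2cc(OC)c(OC)c(OC)c2)cc1O` gives 280 nM, the lowest number of the three. Compound 3 `C/C=C/C(=O)N(Cc1ccc(OC)c(Br)c1)c1cc(OC)c(OC)c(OC)c1` gives 10500 nM, and compound 2 `COC(=O)c1cc(CNc2cc(OC)c(OC)c(OC)c2)ccc1OC` gives 41100 nM; both gaps to compound 1 lie beyond the scatter, so compound 1 is the strongest inhibitor among these three. Compound 4 `C=CC(=O)N(Cc1ccc(OC)c(O)c1)c1cc(OC)c(OC)c(OC)c1` has not yet been measured. It differs from compound 1 in a single place: vinyl in place of 2-methylprop-1-en-1-yl on a carbonyl carbon. Among the measured compounds shown here, no measured pair isolates this change, so only a small step is expected in this assay, if anything toward a lower number: a 1.4-fold lower number from compound 1 to compound 4 (0.15 log units; within the scatter). On that basis compound 4 is expected to give about 200 nM, with a range from 60 nM to 800 nM.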

Compound 4, half-maximal inhibitory concentration: 160 nM
For compound 4 the middle estimate is 1.3-fold (0.10 log units) above the measured one; the measured number falls inside the stated range.
By their numbers in this assay, from the lowest: compounds 4 and 1 (each within the scatter of the next); then compound 3; then compound 2.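

In this assay, vinyl in place of 2-methylprop-1-en-1-yl on a carbonyl carbon gives a 1.8-fold lower number from compound 1 to compound 4 (0.24 log units; within the scatter), the first single-place comparison available in this series. The two groups, of 4 and 2 heavy atoms, therefore cannot be told apart at this place in this assay. No available evidence bears on why they read alike. Going by these compounds, what remains open is whether a saturated ethyl group, which keeps the size of vinyl without its double bond, would read the same. A longer chain, a phenyl ring or an amine at this place is equally unresolved.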